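The source may report more compounds than this note shows. Statements on the series, on what has been measured and on what is new or still open speak of the compounds shown alone.

Two hydroxamic acids have so far been measured in an assay on isolated protein for inhibition of histone deacetylase 8 (Homo sapiens); on this read-out lower numbers stand for stronger inhibition and higher numbers for weaker inhibition. Compound 1, `O=C(CCCCCCCN1C(=O)c2ccccc2C1=O)NO`, gives 71.4 nM. Compound 2, `O=C(CCCCCC(=O)c1ccccc1)NO`, gives 1500 nM, the higher of the two numbers, so compound 2 is the weaker inhibitor of the pair; its gap to compound 1 lies well beyond the usual scatter. The two structures differ in several places at once, so these two values alone do not show which part of either structure carries the difference.

Compound 3, `O=C(CCCCCCC(=O)c1ccccc1)NO`, is not yet measured. It differs from compound 2 in a single place: (hydroxycarbamoyl)methyl in place of hydroxycarbamoyl on a saturated chain carbon, five bonds along the chain from a carbonyl carbon. Among the compounds with values here, no measured pair shows this kind of change, so the expectation rests on compound 2 alone. A step from compound 2 to compound 3 of a 1.7-fold lower number from compound 2 to compound 3 (0.22 log units; within the scatter) is expected, a small move toward stronger inhibition that may not exceed the scatter. For compound 3 a value of 900 nM is estimated, within 300 nM to 3000 nM.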

Compound 3, half-maximal inhibitory concentration: 500 nM
Compound 3: middle estimate off by 1.8-fold (0.26 log units), on the high side, and the stated range covers the measured number.
By their numbers in this assay, from the lowest: compound 1; then compound 3; then compound 2.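

In this assay the change from hydroxycarbamoyl to (hydroxycarbamoyl)methyl on a saturated chain carbon, five bonds along the chain from a carbonyl carbon, gives a 3.0-fold lower number from compound 2 to compound 3 (0.48 log units; beyond the scatter) and so moves inhibition measurably in the stronger direction. Within the data shown here, this is the first single-place comparison, and it shows that the potency of these hydroxamic acids responds to a small change at this position: the entering group holds 2 carbon atoms where the leaving group holds 1, while the counts of hydrogen-bond donors and acceptors stay the same and neither group has a net charge. Nothing available explains why this step occurs.

As far as these compounds go, whether 2-(hydroxycarbamoyl)ethyl at the same place would give a still lower number or reverse the trend remains open. So does the effect of a carboxylic acid in place of the hydroxycarbamoyl end of the chain.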